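A Halogen Swap at the Weak End of the Assay

A few compounds are considered here, and "the series" means these few. Any claim that something is new, unique, unknown or untested is made for them only; others in the source may bear on it.

Three compounds share one core and differ only in the aryl group attached to the carbonyl carbon of an amide. Compound 1 `O=C(Nc1ccc(Cl)c(-c2nnc3c(Cl)cccn23)c1)c1ccc(F)cc1Cl` carries a 2-chloro-4-fluorophenyl group there, and in a functional assay on MDA-MB-231 cells (Homo sapiens) for antiproliferative activity, read by MTT assay, with stated times of 72 h and 4 h (on this read-out higher numbers stand for weaker inhibition and lower numbers for stronger inhibition), compound 1 gives 75000 nM. Compound 2 `O=C(Nc1ccc(Cl)c(-c2nnc3c(Cl)cccn23)c1)c1cccnc1` has a pyridin-3-yl group instead. In this assay compound 2 gives > 100000 nM, which is a limit of the assay and not a number. Compound 3 `O=C(Nc1ccc(Cl)c(-c2nnc3c(Cl)cccn23)c1)c1ccc(Cl)cc1Cl` has a 2,4-dichlorophenyl group. In this assay compound 3 gives > 100000 nM, again a limit rather than a number, so compound 3 stands at the weak end of what the assay can resolve, as shown by the limit of > 100000 nM in this assay, at which 2 of the 3 values shown sit. The measured steps are small or unreadable: an at least 1.3-fold higher number from compound 1 to compound 3 (0.12 log units; that floor lies within the scatter), an at least 1.3-fold higher number from compound 1 to compound 2 (0.12 log units; that floor lies within the scatter), while a step that the two limits leave unreadable from compound 2 to compound 3. Compound 4 `O=C(Nc1ccc(Cl)c(-c2nnc3c(Cl)cccn23)c1)c1c(F)cccc1Cl` is not yet measured, and it differs from compound 3 by 2-chloro-6-fluorophenyl in place of 2,4-dichlorophenyl on a carbonyl carbon. The closest comparison, the exchange of one halogen for another from compound 1 to compound 3, gave only a floor that lies within the scatter, so no step beyond the scatter is expected in this assay. Compound 4 is therefore expected to give 100000 nM, between 40000 nM and 300000 nM, an expected step of a number no higher from compound 3 to compound 4 (the limit leaves the size open), with a limit as the most likely outcome.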

Compound 4, half-maximal inhibitory concentration: > 100000 nM
Compound 4 was reported as a limit; the forecaster's own chance of this, stated with the estimate: 65%; the middle value lies on the limit itself.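

Exchanging the 2-chloro-4-fluorophenyl group for the 2-chloro-6-fluorophenyl group on the carbonyl carbon gives an at least 1.3-fold higher number from compound 1 to compound 4 (0.12 log units; that floor lies within the scatter), so keeping the same two halogens on the ring but placing the fluoro differently produces no change that can be told from noise. The steps from compound 2 and from compound 3 to compound 4 cannot be read, as each joins two limits. Compound 4 shows that a third aryl group on this carbonyl carbon, one carrying a fluoro where compound 3 carries none at that place in its name, also ends at the weak edge of this assay: the limit of > 100000 nM in this assay, at which 3 of the 4 values shown sit.

The compounds shown leave open whether a group of another kind on this carbonyl carbon, such as a piperidine, a carboxylic acid or a longer alkyl chain, would give a number clearly lower than the one for compound 1, which gives 75000 nM in this assay. From the compounds shown here alone, with a single true number among the four values, they also give no ranking of the aryl groups, and what a change in the shared core would do remains unknown.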